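Aryl variation on a shared pyranone core and cell growth

The compounds below may be only part of what the source reports. "The series", "measured", "known", "first", "only" and "open" are said of these compounds alone.

The series shares one core and differs only in the aryl group attached to it. Compound 1, `CCC1=C(O)c2c(oc(-c3cccc(OC(F)(F)F)c3)cc2=O)C(CC)(CC)C1=O`, carries a 3-(trifluoromethoxy)phenyl group. In a functional assay on KB cells (Homo sapiens) for antiproliferative activity, read by sulforhodamine B assay, with a stated time of 3 days (on this read-out higher numbers stand for an effect only at larger amounts of compound and lower numbers for an effect already at smaller amounts), compound 1 gives only a limit, > 47.4 uM, and no number; this is the situation described by the limit of > 47.4 uM in this assay, at which 1 of the 3 values shown sits. Compound 2, `CCC1=C(O)c2c(oc(-c3ccccc3C)cc2=O)C(CC)(CC)C1=O`, carries a 2-methylphenyl group and in this assay compound 2 gives 40.9 uM. Compound 3, `CCC1=C(O)c2c(oc(-c3cc(Cl)c(OC)c(OC)c3)cc2=O)C(CC)(CC)C1=O`, carries a 3-chloro-4,5-dimethoxyphenyl group and in this assay compound 3 gives 21.8 uM. Of the two numbers available, compound 2 sits alongside compound 3, the two values lying within the usual scatter of each other, so no order between them is claimed.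

Compound 4, `CCC1=C(O)c2c(oc(-c3cc(C)cc(C)c3)cc2=O)C(CC)(CC)C1=O`, has not yet been measured. It differs from compound 2 in one place: 3,5-dimethylphenyl in place of 2-methylphenyl on an aromatic carbon. Among the measured compounds shown here, no measured pair in this set isolates such a change, so the expected step is small, with no direction favoured beyond the scatter. The step of a 1.2-fold lower number from compound 2 to compound 4 (0.07 log units; within the scatter) is therefore expected to be modest. Compound 4 is estimated at 35 uM, with a range from 15 uM to 60 uM.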

Compound 4, concentration for half-maximal effect: 45.5 uM
For compound 4 the middle estimate is 1.3-fold (0.11 log units) below the measured one, within the range that was stated.
By their numbers in this assay, from the lowest: compounds 3, 2 and 4 (each within the scatter of the next, the first and the last beyond it). At a limit, above all of these: compound 1.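

Among the compounds shown here, this pair gives the only direct reading at this aromatic carbon, next to the ring oxygen: in this assay, replacing 2-methylphenyl with 3,5-dimethylphenyl gives a 1.1-fold higher number from compound 2 to compound 4 (0.05 log units; within the scatter). Compound 2 and compound 4 therefore cannot be told apart in this assay, so this one change of methyl-bearing phenyl group does not separate them. Compound 1 still gives only a limit, so it offers no number to set beside this pair: the limit of > 47.4 uM in this assay, at which 1 of the 4 values shown sits.

Going by these compounds, whether a clear step at this position can be reached at all remains open, since both aryl groups in the pair carry only methyl groups. An amine or a carboxylic acid on the phenyl ring, or a longer chain such as propyl in place of methyl, might read differently in this assay, and the compounds shown do not say.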